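Trichlorophenyl in place of bromophenyl on the triazole nitrogen

A few compounds are considered here, and "the series" means these few. Any claim that something is new, unique, unknown or untested is made for them only; others in the source may bear on it.

Compound 1, `N#CC1=C(N)Oc2c(c3nc4ccccc4nc3c3ccccc23)C12C(=O)N(Cc1cnnn1-c1ccc(S(N)(=O)=O)cc1)c1ccccc12`, reached only the limit > 50000 nM. Compound 2, `N#CC1=C(N)Oc2c(c3nc4ccccc4nc3c3ccccc23)C12C(=O)N(Cc1cnnn1-c1cccc(S(N)(=O)=O)c1)c1ccccc12`, gave 38600 nM. Compound 3, `N#CC1=C(N)Oc2c(N)cc3nc4ccccc4nc3c2C12C(=O)N(Cc1cnnn1-c1ccccc1Br)c1ccccc12`, gave 34200 nM.

These three compounds were measured in an ADME assay on HUVEC cells (Homo sapiens) for antiproliferative activity, read by MTT assay, with a stated time of 48 h; a lower number here means a stronger inhibitor, a higher number a weaker inhibitor. Compound 3 has the lowest of the two numbers, but its nearest neighbour, compound 2, sits within the scatter of it, so no order between them can be claimed. The value of compound 1 is a limit of the assay, and the limit of > 50000 nM in this assay, at which 1 of the 3 values shown sits, is the only such limit among the three.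

Compound 4, `N#CC1=C(N)Oc2c(N)cc3nc4ccccc4nc3c2C12C(=O)N(Cc1cnnn1-c1c(Cl)cc(Cl)cc1Cl)c1ccccc12`, has not yet been measured. It differs from compound 3 in one place: 2,4,6-trichlorophenyl in place of 2-bromophenyl on an aromatic nitrogen. Going by the values given here, the only measured step, an at least 1.2-fold lower number from compound 1 to compound 2 (0.11 log units; that floor lies within the scatter), concerns a different pair of groups on the same aromatic nitrogen and lies within the scatter; no step exchanges one halogenated phenyl for another. The data therefore give no ground to expect a step beyond the scatter in this assay in either direction.

On that basis compound 4 is estimated at 35000 nM, with a range from 15000 nM to 80000 nM. The step this estimate means, a 1.0-fold higher number from compound 3 to compound 4 (0.01 log units; within the scatter), is expected to stay within the scatter.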

Compound 4, half-maximal inhibitory concentration: 18300 nM
Compound 4: middle estimate off by 1.9-fold (0.28 log units), on the high side, and the stated range covers the measured number.
By their numbers in this assay, from the lowest: compounds 4, 3 and 2 (each within the scatter of the next, the first and the last beyond it). At a limit, above all of these: compound 1.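

In this assay, replacing 2-bromophenyl with 2,4,6-trichlorophenyl on the aromatic nitrogen of the five-membered ring gives a 1.9-fold lower number from compound 3 to compound 4 (0.27 log units; within the scatter), so these two groups cannot be told apart at this position. This is the first step shown that exchanges one halogenated phenyl for another on the core of compound 3, whereas the earlier step concerned only two sulfamoylphenyl groups on the core of compound 1. It shows that, for this pair, three chlorine atoms on the phenyl ring in place of one bromine atom leave the number within the scatter, and no measured property among the data accounts for the size of this step.

The compounds shown leave open whether an unsubstituted phenyl, a phenyl bearing an amine or a carboxylic acid, or a simple alkyl chain on this nitrogen would give a step beyond the scatter. They also leave open how 2-bromophenyl or 2,4,6-trichlorophenyl would read on the core of compound 1, or a sulfamoylphenyl group on the core of compound 3.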